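The source may report more compounds than this note shows. Statements on the series, on what has been measured and on what is new or still open speak of the compounds shown alone.

Measured so far in a functional assay on MCF7 cells (Homo sapiens) for cytotoxicity, read by MTT assay; on this read-out lower numbers stand for stronger inhibition and higher numbers for weaker inhibition:
compound 1 `Cc1oc2c3c(ccc2c(=O)c1C)OC[C@H]1[C@@H]3c2c(ccc(C(=O)Cc3ccccc3)c2O)OC1(C)C`: a limit of the assay, > 100000 nM
compound 2 `Cc1coc2c3c(ccc2c1=O)OC[C@H]1[C@@H]3c2c(ccc(C(=O)Cc3ccccc3)c2O)OC1(C)C`: a limit of the assay, > 100000 nM
compound 3 `Cc1oc2c3c(ccc2c(=O)c1C)OC[C@H]1[C@@H]3c2ccc3ccccc3c2OC1(C)C`: a limit of the assay, > 100000 nM

None of the three values is a number; each is only a limit. All values shown sit at one and the same limit (the limit of > 100000 nM in this assay, at which 3 of the 3 values shown sit). Compound 1 and compound 2 differ by hydrogen in place of methyl on an aromatic carbon, and the step this makes, a step that the two limits leave unreadable from compound 1 to compound 2, cannot be read because both ends are limits.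

Compound 4 `Cc1coc2c3c(ccc2c1=O)OC[C@H]1[C@@H]3c2ccc3ccccc3c2OC1(C)C` is not yet measured in this assay. It differs from compound 3 by hydrogen in place of methyl on an aromatic carbon. The place matches the change from compound 1 to compound 2 in every printed word except that the ring belongs to a fused or bridged system of six rings rather than five, so the two changes are the same kind of change, not the same. How the core of compound 3 differs from the core of compound 1 is not broken down here.

For compound 3 only a limit is known. The step from compound 3 to compound 4 is expected to be a number no higher from compound 3 to compound 4 (the limit leaves the size open), resting on the unreadable step that the two limits leave unreadable from compound 1 to compound 2, which gives no sign that removing this methyl brings a value below the limit. Compound 4 is therefore expected at 100000 nM, in a range from 40000 nM to 300000 nM, most likely again reported only as a limit.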

Compound 4, half-maximal inhibitory concentration: > 100000 nM
Compound 4: only a limit was reported; the forecaster's own chance of this, stated with the estimate: 85%; the middle value lies on the limit itself.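

In this assay compound 4 gives > 100000 nM as a limit of the assay and not a number. Compound 3 is also known only as a limit, so no new step can be read between compound 3 and compound 4. The compounds shown leave open whether hydrogen in place of methyl changes cytotoxicity at all, since every value sits at one point: the limit of > 100000 nM in this assay, at which 4 of the 4 values shown sit.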